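Bromo to Nitrooxy: What to Expect for Compound 4

A few compounds are considered here, and "the series" means these few. Any claim that something is new, unique, unknown or untested is made for them only; others in the source may bear on it.

Measured so far, in a functional assay on the whole organism (strain albino) for inhibition, with Rattus norvegicus as the target, read by paw edema, with stated times of 30 min and 2 h, at a dose of 100 mg/kg by the oral route; a higher number here means more inhibition at the dose given (going by the name of the read-out), a lower number less inhibition:
compound 1, `COc1ccc(C2=NN(C(=O)CBr)C(c3c(Cl)cccc3Cl)C2)cc1`, gives 49%;
compound 2, `COc1ccc(C2=NN(C(=O)CO[N+](=O)[O-])C(c3c(Cl)cccc3Cl)C2)cc1`, gives 42%;
compound 3, `COc1ccc(C2=NN(C(=O)C(C)Br)C(c3ccco3)C2)cc1OC`, gives 36%.

Compound 1 and compound 2 share a core and differ in one place only. The change is nitrooxy in place of bromo on a saturated chain carbon bound to a carbonyl carbon. In this assay this change made a step of a number 7 percentage points lower from compound 1 to compound 2 (within the scatter), so the two values are not told apart by this kind of measurement.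

Compound 3 is built on a different core; the difference between the core of compound 3 and the core of compound 1 is not broken down here. Compound 4, `COc1ccc(C2=NN(C(=O)C(C)O[N+](=O)[O-])C(c3ccco3)C2)cc1OC`, is not yet measured. It differs from compound 3 by nitrooxy in place of bromo on a saturated chain carbon bound to a carbonyl carbon and a saturated chain carbon. Among the compounds with values here, this is the same kind of change as the one from compound 1 to compound 2, but not the same: in compound 1 the changed carbon is bound to a carbonyl carbon, while in compound 3 it is bound to a carbonyl carbon and a saturated chain carbon.

Because the measured step is a number 7 percentage points lower from compound 1 to compound 2 (within the scatter), the expectation for compound 4 in this assay is a step of a number 6 percentage points lower from compound 3 to compound 4 (within the scatter), of similar small size. Compound 4 is therefore estimated at 30%, expected to lie between 18% and 44%. This rests on a single measured pair, and the different surroundings of the changed carbon add uncertainty.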

Compound 4, a percentage reported as inhibition, in the whole organism at one dose (the size of the read-out at that dose, not a potency): 39%
For compound 4 the middle estimate is 9 percentage points below the measured one; low and high end bracket the measured number.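

In this assay, putting nitrooxy in place of bromo on the core of compound 3 gave a number 3 percentage points higher from compound 3 to compound 4 (within the scatter) and so leaves compound 3 and compound 4 not told apart by this kind of measurement. Set beside the earlier pair, the same kind of change shows no detectable dependence on the core, since neither step can be separated from the scatter and the two steps cannot be separated from each other: the same change on two cores in this assay, a number 7 percentage points lower (within the scatter) from compound 1 to compound 2 and a number 3 percentage points higher (within the scatter) from compound 3 to compound 4, 10 percentage points apart, within the scatter of two such steps. This does not show that bromo and nitrooxy are truly equivalent, as a small real effect of the change could be hidden in the scatter, and two pairs, with different surroundings at the changed carbon, are too few to predict what would happen on a further core.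

The compounds shown leave open whether a group of a different kind, such as an amine or a carboxylic acid, would give a clear step from the same saturated chain carbon. They also leave open whether a longer chain in place of 1-(nitrooxy)ethyl would keep the value of compound 4 within the scatter.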